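This account rests on a few compounds, and the source may have more. Where it says the series, first, only, none or still open, it means among the compounds named here.

Measured so far in an assay on cells for inhibition of Amine oxidase [flavin-containing] B (Homo sapiens), read by fluorescence, with stated times of 10 min and 20 min, tested at 25 uM; a higher number here means more inhibition at the concentration tested (going by the name of the read-out), a lower number less inhibition:
compound 1 `COc1c(C)c(C/C=C(\C)CC/C=C(\C)CCC=C(C)C)c(OC)c(OC)c1OC` gives 15.2%
compound 2 `COc1cc(C)c(C/C=C(\C)CC/C=C(\C)CCC=C(C)C)c(OC)c1OC` gives 34.9%
compound 3 `COc1cc(C)c(CC=C(C)C)c(OC)c1` gives 5.4%

Compounds 1 and 2 share the long-chain core and differ in one place: methoxy in place of hydrogen on an aromatic carbon. That change gives a number 19.7 percentage points lower from compound 2 to compound 1 (beyond the scatter). Compound 3 carries a 3-methylbut-2-en-1-yl group on its core; the difference between the cores of compound 2 and compound 3 is not broken down here. Compound 3 sits lowest of the three numbers, within the scatter of compound 1 and beyond the scatter of compound 2.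

Compound 4 `COc1cc(C)c(CC=C(C)C)c(OC)c1OC` is not yet measured. It differs from compound 3 in one place: methoxy in place of hydrogen on an aromatic carbon. Going by the values given here, this is the same kind of change as the one from compound 2 to compound 1, not the same change: in compound 4 the incoming methoxy sits ortho to two methoxy groups, meta to a 3-methylbut-2-en-1-yl group and para to a methyl group, whereas in compound 1 it sits ortho to a methoxy group, ortho to a methyl group, meta to a large group, meta to a methoxy group and para to a methoxy group.

For compound 4 the step in this assay is estimated as a number 2.4 percentage points lower from compound 3 to compound 4 (within the scatter), resting on the earlier step of a number 19.7 percentage points lower from compound 2 to compound 1 (beyond the scatter) and on compound 3 already giving 5.4%, which leaves little room for a fall of that size. Compound 4 is therefore estimated at 3%, between -7% and 14%.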

Compound 4, a percentage reported as inhibition, at one concentration (the size of the read-out at that concentration, not a potency): 18.6%
For compound 4 the middle estimate is 15.6 percentage points below the measured one; measured number above the stated range.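

In this assay, methoxy in place of hydrogen on an aromatic carbon gives a number 13.2 percentage points higher from compound 3 to compound 4 (beyond the scatter), so the change does not carry over from the long-chain core in direction or size: the same change on two cores in this assay, a number 19.7 percentage points lower (beyond the scatter) from compound 2 to compound 1 and a number 13.2 percentage points higher (beyond the scatter) from compound 3 to compound 4, 32.9 percentage points apart, beyond the scatter of two such steps

In this series, then, the result of this change cannot be transferred from one core to another, and a step measured on one core is a poor guide to the step on the other. The two pairs differ both in the chain on the core and in the surroundings of the incoming methoxy, which in compound 4 sits ortho to two methoxy groups, meta to a 3-methylbut-2-en-1-yl group and para to a methyl group, so they do not show which of these differences matters, and single-concentration readings say nothing about potency.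

Still open, going by these compounds, is whether a methoxy entering the long-chain core in the same surroundings as in compound 4 would follow the step seen on the short-chain core. Also open, on these data alone, is how a geranyl chain on the same core would behave, and whether a hydroxy group or an ethoxy group in place of the incoming methoxy would give a step in the same direction.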